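A few compounds are considered here, and "the series" means these few. Any claim that something is new, unique, unknown or untested is made for them only; others in the source may bear on it.

Measured so far in an assay on isolated protein with retinoic acid receptor alpha (Homo sapiens) as the target, read by TR-FRET, with a stated time of 4 h; on this read-out lower numbers stand for an effect already at smaller amounts and higher numbers for an effect only at larger amounts of compound:

Compound 1 `CCOC(=O)c1ccc(-c2nc(-c3ccc4c(c3)C(C)(C)CCC4(C)C)c(C)s2)cc1`: 88.9 nM
Compound 2 `CCOCCOc1nc(-c2ccc(C(=O)O)cc2)sc1C`: 15.1 nM
Compound 3 `Cc1sc(-c2ccc(C(=O)O)cc2)nc1-c1ccccc1`: 77.5 nM

Compound 3 stands second highest of the three numbers. Its value and that of compound 1 lie within the usual scatter of each other, so the two cannot be told apart. Compound 2 gives the lowest number, and the step of a 5.1-fold higher number from compound 2 to compound 3 (0.71 log units; beyond the scatter) lies beyond the scatter.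

Compound 4 `CCOC(=O)c1ccc(-c2nc(-c3ccccc3)c(C)s2)cc1` is not yet measured. It differs from compound 3 in one place: ethyl in place of hydrogen on an oxygen next to a carbonyl group; read one bond further out, a carboxy becomes an ethoxycarbonyl. Among the measured compounds shown here, no measured step isolates this change. For the measured compounds named here, the only compound carrying an ethoxycarbonyl group, compound 1, also differs from compound 3 elsewhere, and its value sits within the scatter of compound 3, so it offers no direction. The step of a 1.9-fold higher number from compound 3 to compound 4 (0.29 log units; within the scatter) is therefore expected to be small, with a slight lean toward a higher number. Compound 4 is estimated at 150 nM, in the range 50 nM to 500 nM.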

Compound 4, half-maximal effective concentration: 82 nM
The estimate for compound 4 lay 1.8-fold (0.26 log units) above the measured number; the range from low to high includes it.
By their numbers in this assay, from the lowest: compound 2; then compounds 3, 4 and 1 (each within the scatter of the next).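

In this assay, the first direct test of this position gives a 1.1-fold higher number from compound 3 to compound 4 (0.02 log units; within the scatter) when ethyl replaces the hydrogen on the oxygen next to the carbonyl group, turning carboxy into ethoxycarbonyl. On this pair, therefore, the free carboxy group and its ethyl ester cannot be told apart, a reading that compound 1 could not give because it also differs from compound 3 elsewhere. Nothing available explains why this change leaves no readable difference.

As far as these compounds go, whether the same change would also leave no readable difference with the 2-ethoxyethoxy group of compound 2 or the larger group of compound 1 remains open. It is also unknown how this position would respond to an amide in place of the ester, or to a longer chain such as butyl in place of ethyl.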